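Working notes: methyl in place of chloro at compound 4

This account rests on a few compounds, and the source may have more. Where it says the series, first, only, none or still open, it means among the compounds named here.

The three measured compounds share one core and differ on the six-membered aromatic ring with 1 nitrogen. Compound 1 `O=C(CCCc1ccc(F)cn1)N1CCc2c(Cl)c(O)c(O)c(Cl)c2C1` gives 89% in a functional assay (Homo sapiens), tested at 1 uM; a lower number here means a stronger effect, a higher number a weaker effect of the compound at the concentration tested. Compound 2 `O=C(CCCc1ccc(C(F)(F)F)cn1)N1CCc2c(Cl)c(O)c(O)c(Cl)c2C1` gives 72% in this assay, the step being a number 17 percentage points lower from compound 1 to compound 2 (beyond the scatter). Compound 3 `O=C(CCCc1ncc(C(F)(F)F)cc1Cl)N1CCc2c(Cl)c(O)c(O)c(Cl)c2C1` gives 61% in this assay, the lowest of the three numbers, reached by a number 11 percentage points lower from compound 2 to compound 3 (beyond the scatter).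

Compound 4 `Cc1cc(C(F)(F)F)cnc1CCCC(=O)N1CCc2c(Cl)c(O)c(O)c(Cl)c2C1` differs from compound 3 in one place: methyl in place of chloro on an aromatic carbon. Within the data shown here, no measured pair exchanges chloro for methyl, so the only step that bears on this change is a number 11 percentage points lower from compound 2 to compound 3 (beyond the scatter), where chloro entered at this position in place of hydrogen. Since methyl, like chloro, brings one heavy atom and no donor or acceptor, the expected step in this assay is small, in either direction, and likely within the scatter. Compound 4 is estimated at 64%, between 50% and 80%, which means an expected step of a number 3 percentage points higher from compound 3 to compound 4 (within the scatter).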

Compound 4, a percentage reported as activity, at one concentration (the size of the read-out at that concentration, not a potency): 67%
Beside the measured number, compound 4's estimate is 3 percentage points below it; measured number inside the range.
By their numbers in this assay, from the lowest: compounds 3, 4 and 2 (each within the scatter of the next, the first and the last beyond it); then compound 1.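

With methyl on this aromatic carbon, ortho to a large group and two atoms from the ring nitrogen, this assay gives a number 5 percentage points lower from compound 2 to compound 4 (within the scatter), so methyl in place of hydrogen does not register as a step beyond the scatter, whereas chloro in place of hydrogen did in a number 11 percentage points lower from compound 2 to compound 3 (beyond the scatter). The exchange of chloro for methyl gives a number 6 percentage points higher from compound 3 to compound 4 (within the scatter), which leaves compound 4 within the scatter of both compound 2 and compound 3, so methyl cannot be assigned to either side of the chloro-hydrogen difference. No data on any property of these groups bear on this result, and it carries no explanation.

On these data alone, whether a methoxy group or a nitrile on this carbon would move the number beyond the scatter from compound 3 remains open. Also open, as far as these compounds go, is whether the chloro step holds with fluoro in place of trifluoromethyl.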